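Swapping the Amine Substituent: Expectation for Compound 4

The compounds below may be only part of what the source reports. "The series", "measured", "known", "first", "only" and "open" are said of these compounds alone.

Measured so far in a functional assay on MCF7 cells (Homo sapiens) for antiproliferative activity; a higher number here means a weaker inhibitor, a lower number a stronger inhibitor:
- compound 1, `CC(C)=CCc1cc(C(=O)Nc2cc3ccc(OCCCN4CCCCC4)c(C)c3oc2=O)ccc1O`, gives > 50000 nM, which is a limit of the assay.
- compound 2, `CCN(C)CCCOc1ccc2cc(NC(=O)c3ccc(O)c(CC=C(C)C)c3)c(=O)oc2c1C`, gives 2190 nM.
- compound 3, `CC(C)=CCc1cc(C(=O)Nc2cc3ccc(OCCCNC(C)(C)C)c(C)c3oc2=O)ccc1O`, gives 950 nM.

Compound 3 holds the lowest of the two numbers shown, with the step of a 2.3-fold lower number from compound 2 to compound 3 (0.36 log units; beyond the scatter) separating it from compound 2. The value of compound 1 is a limit, (the limit of > 50000 nM in this assay, at which 1 of the 3 values shown sits), so the steps of an at least 22-fold lower number from compound 1 to compound 2 (1.35 log units; beyond the scatter) and an at least 52-fold lower number from compound 1 to compound 3 (1.72 log units; beyond the scatter) are known only as minimum sizes.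

Compound 4, `CC(C)=CCc1cc(C(=O)Nc2cc3ccc(OCCCN[C@H](C)c4ccccc4)c(C)c3oc2=O)ccc1O`, differs from compound 3 in one place: 1-phenylethyl in place of tert-butyl on an amine nitrogen. All three measured steps change the substituent on this amine nitrogen, and each changed the number in this assay, two of them by a large margin from the piperidin-1-yl compound and one modestly between the two open-chain amines. None of them compares one secondary amine bearing an alkyl group with another bearing a 1-phenylethyl group, so the direction is uncertain. Compound 4 is therefore expected to show a step of about a 1.2-fold lower number from compound 3 to compound 4 (0.07 log units; within the scatter), within or close to the scatter. The estimate for compound 4 is 800 nM, with a range from 250 nM to 2500 nM.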

Compound 4, half-maximal inhibitory concentration: 1450 nM
Compound 4: middle estimate off by 1.8-fold (0.26 log units), on the low side, within the range that was stated.
By their numbers in this assay, from the lowest: compounds 3, 4 and 2 (each within the scatter of the next, the first and the last beyond it). At a limit, above all of these: compound 1.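

In this assay, 1-phenylethyl on the amine nitrogen brings a six-membered aromatic ring and a defined stereocentre, yet the comparisons, a 1.5-fold higher number from compound 3 to compound 4 (0.18 log units; within the scatter) and a 1.5-fold lower number from compound 2 to compound 4 (0.18 log units; within the scatter), both stay within the scatter, so the aromatic ring on this nitrogen sets compound 4 apart from neither open-chain amine. Only the piperidin-1-yl compound stands apart among the four, with an at least 34-fold lower number from compound 1 to compound 4 (1.53 log units; beyond the scatter), a step known only as a minimum size. The value of compound 1 is a limit of the assay: the limit of > 50000 nM in this assay, at which 1 of the 4 values shown sits.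

The compounds shown leave open whether the opposite configuration at the stereocentre, or a plain benzyl group on the same nitrogen, would give a similar number. They also leave open whether another cyclic amine, such as pyrrolidin-1-yl or morpholin-4-yl, would share the result of compound 1.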